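Swapping a Triazole for an Imidazole on the Shared Core

This account rests on a few compounds, and the source may have more. Where it says the series, first, only, none or still open, it means among the compounds named here.

Compound 1 `CC(c1ccc(Nc2ccccc2)cc1)n1cncn1` is the starting point. In an assay on MCF7 cells for inhibition of cytochrome P450 26A1 (Homo sapiens) (a higher number here means a weaker inhibitor, a lower number a stronger inhibitor), compound 1 gives only a limit, > 50000 nM, which is the limit described as the limit of > 50000 nM in this assay, at which 1 of the 2 values shown sits. Compound 2 `c1ccc(Nc2ccc(C(c3ccccc3)n3cncn3)cc2)cc1` carries a phenyl where compound 1 carries a methyl, and in this assay compound 2 gives 5000 nM; that change produced an at least 10-fold lower number from compound 1 to compound 2 (1.00 log units; beyond the scatter). Compound 3 `CC(c1ccc(Nc2ccccc2)cc1)n1ccnc1` makes a different change: 1H-imidazol-1-yl in place of 1H-1,2,4-triazol-1-yl on a saturated chain carbon bound to an aromatic carbon and a saturated chain carbon. Among the compounds with values here, no measured step touches this swap, so the data give no direction for it. Compound 3 is therefore expected near 30000 nM (range 5000 nM to 100000 nM), an expected step of an at least 1.6-fold lower number from compound 1 to compound 3 (0.22 log units; that floor lies within the scatter).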

Compound 3, half-maximal inhibitory concentration: 35000 nM
The estimate for compound 3 lay 1.2-fold (0.07 log units) below the measured number, and the stated range covers the measured number.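

Replacing 1H-1,2,4-triazol-1-yl with 1H-imidazol-1-yl on this saturated chain carbon gives the first read on the ring itself: in this assay, the swap gives an at least 1.4-fold lower number from compound 1 to compound 3 (0.15 log units; that floor lies within the scatter). Compound 3 therefore has a measured number, and the step has only a floor. The true size of the step stays unknown because compound 1 gives only a limit: the limit of > 50000 nM in this assay, at which 1 of the 3 values shown sits.

Still open, on these data alone, is whether the phenyl of compound 2 would lower the number with 1H-imidazol-1-yl in place. Also open, as far as these compounds go, is how an amine or a carboxylic acid would fare at this position.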